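The source may report more compounds than this note shows. Statements on the series, on what has been measured and on what is new or still open speak of the compounds shown alone.

Working notes on the series. Compound 1 `CCCS(=O)(=O)Nc1ccc(F)c(C(=O)c2n[nH]c3ncc(-c4ccc(Cl)cc4Cl)cc23)c1F` gives 22% in an assay for binding affinity to dual specificity mitogen-activated protein kinase kinase 4 (Homo sapiens), read by KINOMEscan, tested at 100 nM; a lower number here means a stronger effect, a higher number a weaker effect of the compound at the concentration tested. Within the data shown here, compound 2 `CCCS(=O)(=O)Nc1ccc(F)c(C(=O)c2n[nH]c3ncc(-c4cccc(C(F)(F)F)c4)cc23)c1F` gives 57% in this assay, the highest of the two numbers so far; the step of a number 35 percentage points higher from compound 1 to compound 2 (beyond the scatter) shows that exchanging the group on an aromatic carbon moves the read-out by a large amount. Compound 3 `CCCS(=O)(=O)Nc1ccc(F)c(C(=O)c2n[nH]c3ncc(-c4ccc(C(N)=O)cc4)cc23)c1F` carries 4-carbamoylphenyl in place of 3-(trifluoromethyl)phenyl on an aromatic carbon. Among the measured compounds shown here, only the step from compound 1 to compound 2 bears on this change, and it concerns a different pair of groups, so the direction of a number 3 percentage points higher from compound 2 to compound 3 (within the scatter) is expected to be uncertain and no shift beyond the scatter is assumed. Compound 3 is expected to give 60%, within 25% to 95%.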

Compound 3, a percentage reported as activity, at one concentration (the size of the read-out at that concentration, not a potency): 0.15%
Compound 3: middle estimate off by 59.9 percentage points, on the high side, and the stated range ends above it.
By their numbers in this assay, from the lowest: compound 3; then compound 1; then compound 2.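

The aryl group on this aromatic carbon, para to a fused ring, moves the read-out in this assay in both directions: 4-carbamoylphenyl gives a number 56.9 percentage points lower from compound 2 to compound 3 (beyond the scatter) and a number 21.9 percentage points lower from compound 1 to compound 3 (beyond the scatter) in the other comparison. Compound 3 therefore has the lowest number of the three, with both steps beyond the scatter, so neither earlier group marks the best result at this position. No measurement bears on why this change has such an effect. Still open, from the compounds shown here alone, is whether the carbamoyl group or its placement on the phenyl ring drives the drop, and what a carboxylic acid or a nitrile would give at the same place.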